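A few compounds are considered here, and "the series" means these few. Any claim that something is new, unique, unknown or untested is made for them only; others in the source may bear on it.

Among the measured compounds shown here, compound 1 `COc1ccc(-c2cc(-c3ccc(F)cc3)c(C#N)c(OC)n2)cc1` is the only compound here with a numerical result in an assay on isolated protein for inhibition of sulfide:quinone oxidoreductase, mitochondrial (Homo sapiens); on this read-out higher numbers stand for weaker inhibition and lower numbers for stronger inhibition: compound 1 gives 1360 nM. Compound 2 `COc1nc(-c2ccccc2)cc(-c2ccc(Cl)cc2Cl)c1C#N` gives > 100000 nM in this assay, which is a limit rather than a number (the limit of > 100000 nM in this assay, at which 1 of the 2 values shown sits). Compound 3 `COc1nc(-c2cccnc2)cc(-c2ccc(F)cc2)c1C#N` carries pyridin-3-yl in place of 4-methoxyphenyl on an aromatic carbon. No measured step of this kind exists among the compounds shown, so the direction remains open; the expectation is a small weakening, not far beyond the scatter, for the step from compound 1 to compound 3 a 1.8-fold higher number from compound 1 to compound 3 (0.26 log units; within the scatter). Compound 3 is therefore estimated at 2500 nM in this assay, in a range from 800 nM to 8000 nM.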

Compound 3, half-maximal inhibitory concentration: 213 nM
Estimate against measurement, compound 3: 12-fold (1.07 log units) above; the measured number lies below the stated range.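

In this assay, pyridin-3-yl in place of 4-methoxyphenyl next to the ring nitrogen gives a 6.4-fold lower number from compound 1 to compound 3 (0.81 log units; beyond the scatter) and thus stronger inhibition. This first measured step at this position shows that the 4-methoxyphenyl group is not needed here and that an aromatic ring with a ring nitrogen is accepted. Nothing shown tells whether the gain comes from the added ring nitrogen or the lost methoxy group. Going by these compounds, whether unsubstituted phenyl, pyridin-2-yl or pyridin-4-yl would match pyridin-3-yl stays open. So does the effect of an amine on the pyridin-3-yl ring.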